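Pyridin-3-yl in place of 3,5-difluorophenyl on the cyclopropane

This account rests on a few compounds, and the source may have more. Where it says the series, first, only, none or still open, it means among the compounds named here.

Measured in a functional assay for agonist activity at G protein-coupled receptor 88 (Homo sapiens), read by HTRF and cAMP accumulation; a higher number here means that more compound is needed for the effect, a lower number that less compound is needed:
Compound 1 `CC[C@H](C)[C@H](N)CN(C(=O)[C@@H]1C[C@H]1c1ccccc1Cl)c1ccc(-c2ccccc2)cc1`: in this assay compound 1 gives > 25000 nM, which is a limit, not a number (the limit of > 25000 nM in this assay, at which 1 of the 2 values shown sits).
Compound 2 `CC[C@H](C)[C@H](N)CN(C(=O)[C@@H]1C[C@H]1c1cc(F)cc(F)c1)c1ccc(-c2ccccc2)cc1`: in this assay compound 2 gives 960 nM.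

Compound 2 therefore holds the only number shown. Within the data shown here, the one measured step, an at least 26-fold lower number from compound 1 to compound 2 (1.41 log units; beyond the scatter), shows that the aryl group on the three-membered ring moves the number strongly. Compound 3 `CC[C@H](C)[C@H](N)CN(C(=O)[C@@H]1C[C@H]1c1cccnc1)c1ccc(-c2ccccc2)cc1` carries the change (pyridin-3-yl in place of 3,5-difluorophenyl on a saturated ring carbon). Since that single step swapped both the ring substituents and their pattern, its size offers only a rough guide; a moderate rise in the number is expected, a 3.1-fold higher number from compound 2 to compound 3 (0.49 log units; beyond the scatter). Compound 3 is estimated at 3000 nM, within 700 nM to 15000 nM.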

Compound 3, half-maximal effective concentration: 1500 nM
Estimate against measurement, compound 3: 2.0-fold (0.30 log units) above; the measured number falls inside the stated range.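

Swapping 3,5-difluorophenyl for pyridin-3-yl gives a 1.6-fold higher number from compound 2 to compound 3 (0.19 log units; within the scatter) in this assay, so this position takes a ring with one hetero atom and no fluorine without a change that can be told apart. The step from 2-chlorophenyl remains large with an at least 16-fold lower number from compound 1 to compound 3 (1.22 log units; beyond the scatter) and so does not depend on the fluorine atoms of compound 2. The value of compound 1 is a limit, not a number, so this step has no fixed size: the limit of > 25000 nM in this assay, at which 1 of the 3 values shown sits.

The compounds shown leave open how an amine or a methoxy group on this ring would read. They also leave open whether chlorine itself or its place on the ring separates compound 1 from the others.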